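A few compounds are considered here, and "the series" means these few. Any claim that something is new, unique, unknown or untested is made for them only; others in the source may bear on it.

Among the compounds with values here, in a functional assay on MCF7 cells (Homo sapiens) for antiproliferative activity, read by MTT assay (a lower number here means a stronger inhibitor, a higher number a weaker inhibitor), compound 3 `COc1ccc(-n2cc(COc3ccc(/C=C/C(=O)c4ccc5c(c4O)CCC(C)(C)O5)cc3)nn2)c([N+](=O)[O-])c1` gives 73100 nM, the only number in this small set. Compound 1 `CC1(C)CCc2cc(C(=O)/C=C/c3ccc(OCc4cn(-c5ccc(Br)cc5)nn4)cc3)c(O)cc2O1` is reported as "not active" (no number reported), and compound 2 `CC1(C)CCc2c(ccc(C(=O)/C=C/c3ccc(OCc4cn(-c5ccc(Br)cc5)nn4)cc3)c2O)O1` as "not active" (no number reported), so neither can be ranked numerically against compound 3. Compound 4 `Cc1ccc(-n2cc(COc3ccc(/C=C/C(=O)c4ccc5c(c4O)CCC(C)(C)O5)cc3)nn2)cc1Br` has not yet been measured. It carries 3-bromo-4-methylphenyl in place of 4-methoxy-2-nitrophenyl on an aromatic nitrogen. Within the data shown here, no measured pair shows this change alone, so the expectation is loose. Compound 2 also bears bromine and gives "not active" (no number reported), which offers no reason to expect a gain. The expected step, a 1.1-fold higher number from compound 3 to compound 4 (0.04 log units; within the scatter), stays within the scatter. Compound 4 is estimated at 80000 nM, with an expected range of 30000 nM to 200000 nM.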

Compound 4, half-maximal inhibitory concentration: "not active" (no number reported)
Nothing numeric was reported for compound 4; no gap can be computed for the estimate.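

Within the data shown here, compound 4, like compound 1 and compound 2, has no number, and no step from compound 3 to compound 4 can be read. The compounds shown leave open how 3-bromo-4-methylphenyl compares numerically with 4-methoxy-2-nitrophenyl. Nothing shown speaks to a cause for this result.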